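Methyl removal at the ring carbinol carbon

This account rests on a few compounds, and the source may have more. Where it says the series, first, only, none or still open, it means among the compounds named here.

Measured so far in an assay on HEK293 cells for antagonist activity at transient receptor potential cation channel subfamily V member 3 (Homo sapiens), read by FLIPR and calcium flux; on this read-out lower numbers stand for stronger inhibition and higher numbers for weaker inhibition:
compound 1, `C[C@@]1(c2ccc(OC(F)(F)F)cc2)C[C@@](O)(c2ccccn2)CO1`, gives 1120 nM
compound 2, `C[C@]1(O)C[C@@](c2ccnc(C(F)(F)F)c2)([C@H](O)c2ccccn2)C1`, gives 4270 nM
compound 3, `C[C@]1(O)C[C@](c2ccnc(C(F)(F)F)c2)([C@H](O)c2ccccn2)C1`, gives 500 nM

Compound 3 holds the lowest number of the three in this assay. Compound 3 gives 500 nM, whereas compound 1 gives 1120 nM; compound 2, furthest off, gives 4270 nM. Among the measured compounds shown here, the one step measured within a matched pair is an 8.5-fold lower number from compound 2 to compound 3 (0.93 log units; beyond the scatter), and it rests on (the fact that compounds 2 and 3 differ only in the configuration as drawn); no part of the skeleton changes there.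

Compound 4, `O[C@H](c1ccccn1)[C@]1(c2ccnc(C(F)(F)F)c2)C[C@H](O)C1`, differs from compound 3 by hydrogen in place of methyl on a saturated ring carbon. For the measured compounds named here, no measured step involves a change of this kind: the only step known concerns configuration alone, and compounds 1 and 3 differ in far more than one place, so no size can be drawn from them. The hydroxy group on the ring and the hydroxy(pyridin-2-yl)methyl group are both retained, so a step in this assay of no more than the usual scatter is expected in either direction, with the wider range below reflecting that nothing measured anchors it.

For compound 4 a value of 700 nM is estimated, between 250 nM and 2000 nM, which is expected to amount to a 1.4-fold higher number from compound 3 to compound 4 (0.15 log units; within the scatter).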

Compound 4, antagonist equilibrium constant: 60 nM
Compound 4: middle estimate off by 12-fold (1.07 log units), on the high side, and the stated range ends above it.
By their numbers in this assay, from the lowest: compound 4; then compound 3; then compound 1; then compound 2.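

In this assay, among the compounds shown here, hydrogen in place of methyl on a saturated ring carbon of the four-membered ring gives an 8.3-fold lower number from compound 3 to compound 4 (0.92 log units; beyond the scatter), the first measured step that changes a substituent and not configuration alone. The earlier matched pair, with an 8.5-fold lower number from compound 2 to compound 3 (0.93 log units; beyond the scatter), showed only that the arrangement of the same atoms matters; this result shows that this ring position is also sensitive to its substituent, since the loss of a single carbon moves the number beyond the scatter, and that the methyl group is not needed for a low number in this pair. Nothing measured here accounts for the size of the step or says why the smaller substituent gives the lower number.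

The compounds shown leave open how this ring carbon responds to anything other than methyl and hydrogen, such as an ethyl group, a fluorine atom or an amine in the same place. They also leave open whether the step from methyl to hydrogen keeps its direction and size in the configuration of compound 2.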